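The source may report more compounds than this note shows. Statements on the series, on what has been measured and on what is new or still open speak of the compounds shown alone.

Compound 1 `O=C1c2ccccc2N(Cc2ccccc2)S(=O)(=O)N1Cc1ccccc1` gives in a functional assay on HEL cells (Homo sapiens) (on this read-out higher numbers stand for lower toxicity in this test and lower numbers for higher toxicity in this test), only a limit of the assay, > 50000 nM.
Compound 2 `O=C1c2ccccc2N(Cc2ccccc2)S(=O)(=O)N1COCc1ccccc1` gives in this assay 49000 nM.

Compound 1 thus stands at the edge of what this assay can report, a limit rather than a number (the limit of > 50000 nM in this assay, at which 1 of the 2 values shown sits). Compound 3 `O=C1c2ccccc2N(Cc2ccc(Cl)cc2)S(=O)(=O)N1Cc1ccccc1` differs from compound 1 by chloro in place of hydrogen on an aromatic carbon. For the measured compounds named here, no measured step involves this change; the only known step, an at least 1.0-fold lower number from compound 1 to compound 2 (0.00 log units; that floor lies within the scatter), concerns another part of the molecule and stayed within the scatter. No movement beyond the scatter is therefore expected. Compound 3 is estimated at 45000 nM, between 20000 nM and 100000 nM. This expected estimate means a step of an at least 1.1-fold lower number from compound 1 to compound 3 (0.04 log units; that floor lies within the scatter).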

Compound 3, minimum cytotoxic concentration: > 5000 nM
Compound 3 ended at the assay's limit (the forecaster's own chance of this, stated with the estimate: 50%); the middle value is on the limit's open side.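

For the compounds shown here, compound 1 and compound 3 both end at limits of this assay rather than at numbers, so no step between them can be read. As far as these compounds go, whether 4-chlorobenzyl in place of benzyl alters the read-out remains open.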